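The source may report more compounds than this note shows. Statements on the series, on what has been measured and on what is new or still open speak of the compounds shown alone.

Measured compounds:
compound 1 `O=S(=O)(NCCNCc1ccc(-c2ccccc2)cc1)c1cc(C(F)(F)F)cc(C(F)(F)F)c1` — 1600 nM
compound 2 `O=S(=O)(NCCCNCC1COc2ccccc2O1)c1cc(C(F)(F)F)cc(C(F)(F)F)c1` — 1200 nM
compound 3 `CN(CCCNS(=O)(=O)c1cc(C(F)(F)F)cc(C(F)(F)F)c1)Cc1ccccc1` — 39000 nM

In a functional assay on BXPC-3 cells (Homo sapiens) for inhibition, read by MTT assay, with a stated time of 72 h (on this read-out higher numbers stand for weaker inhibition of growth and lower numbers for stronger inhibition of growth), compound 2 gives the lowest of the three numbers. Compound 1 sits close to it, within the scatter, whereas compound 3 lies far above it, beyond the scatter. Compound 4 `O=S(=O)(NCCCNCc1ccc(Cl)cc1)c1cc(C(F)(F)F)cc(C(F)(F)F)c1` is not yet measured. It differs from compound 2 as follows: 4-chlorophenyl in place of 2,3-dihydro-1,4-benzodioxin-2-yl on a saturated chain carbon bound to an amine nitrogen. The shared core and the chain to the amine nitrogen are kept. Within the data shown here, since no two measured compounds differ in one place only, the size of this step is not known from the data; on the evidence of compound 2 1200 nM and compound 1 1600 nM, a change of this kind is expected to stay within or near the scatter, if anything toward a somewhat higher number. Compound 4 is therefore estimated at 2000 nM, between 700 nM and 6000 nM, a step of a 1.7-fold higher number from compound 2 to compound 4 (0.22 log units; within the scatter).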

Compound 4, concentration for 50% growth inhibition: 1600 nM
Estimate against measurement, compound 4: 1.3-fold (0.10 log units) above; measured number inside the range.
By their numbers in this assay, from the lowest: compounds 2, 1 and 4 (each within the scatter of the next); then compound 3.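

In this assay, 4-chlorophenyl in place of 2,3-dihydro-1,4-benzodioxin-2-yl on a saturated chain carbon bound to an amine nitrogen gives a 1.3-fold higher number from compound 2 to compound 4 (0.12 log units; within the scatter), so at this place the two groups cannot be told apart. By contrast, (4-chlorobenzyl)amino in place of benzyl(methyl)amino gives a 24-fold lower number from compound 3 to compound 4 (1.39 log units; beyond the scatter), which shows that the amine end of the chain can matter greatly. No measurement at hand accounts for either step.

That large step joins two changes, the methyl on the amine and the chlorine, and a plain benzylamino group would be needed to separate them. As far as these compounds go, how a 4-methoxybenzyl group or a longer chain would read also remains open.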